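A few compounds are considered here, and "the series" means these few. Any claim that something is new, unique, unknown or untested is made for them only; others in the source may bear on it.

Working notes on the series. Of the compounds shown here, two have numbers so far. Compound 1, `CNCCN(C)c1nnnn1Cc1cccc(OC(F)(F)F)c1`, gives 12% in an assay on cells for inhibition of protein arginine N-methyltransferase 1 (Homo sapiens), read by scintillation counting, with stated times of 15 min and 60 min, tested at 9 uM; a lower number here means less inhibition, a higher number more inhibition at the concentration tested (going by the name of the read-out). Compound 2, `COC(=O)c1cccc(-c2ccc(CN(C)CCN)o2)c1`, gives 38% in this assay, the higher of the two numbers; its gap to compound 1 lies beyond the scatter, so the inhibition in this assay is higher for compound 2 than for compound 1. Compound 3, `CN(CCN)Cc1ccc(-c2cccc(C#N)c2)o1`, is the next one to go into this assay and has not yet been measured. It differs from compound 2 in one place: cyano in place of methoxycarbonyl on an aromatic carbon. Going by the values given here, no pair of measured compounds shows a change of this kind, so there is no measured step to lean on. With a change of this size in this part of the core, the expected step in this assay from compound 2 to compound 3 is small, a number 6 percentage points lower from compound 2 to compound 3 (within the scatter), and may fall within the scatter in either direction. Compound 3 is thus expected to give 32% in this assay, within a range from 10% to 55%.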

Compound 3, a percentage reported as inhibition, at one concentration (the size of the read-out at that concentration, not a potency): 38%
Compound 3: the middle estimate sits 6 percentage points below what was measured; the range from low to high includes it.
By their numbers in this assay, from the lowest: compound 1; then compounds 2 and 3 (each within the scatter of the next).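

In this assay, going by these compounds alone, the step reads no change at the digits printed from compound 2 to compound 3 (within the scatter) and is the first measured step at this place, on an aromatic carbon of a six-membered aromatic ring of carbon only, meta to a large group. Methoxycarbonyl, with 4 heavy atoms and 2 hydrogen-bond acceptors, can therefore be exchanged for cyano, with 2 heavy atoms and 1 hydrogen-bond acceptor, without a difference beyond the scatter, so the carbonyl of the ester is not required here to hold this level of inhibition. No measurement at hand accounts for this result.

The compounds shown leave open whether a carboxylic acid, a primary amide or a plain hydrogen at this place would read the same, and thus whether any group is needed here at all. They also leave open how a longer chain on the amine of the shared core would read.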